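Trimming a Benzyl Arm Down to Methyl

This account rests on a few compounds, and the source may have more. Where it says the series, first, only, none or still open, it means among the compounds named here.

Within the data shown here, in an assay on isolated protein for activation of cGMP-dependent protein kinase 1 (Homo sapiens), read by ADP-Glo, with stated times of 120 min and 40 min (on this read-out higher numbers stand for an effect only at larger amounts of compound and lower numbers for an effect already at smaller amounts), compound 2 `O=C(O)c1ccc(CN2CCC[C@H](O[C@H](CO)c3cc(Cl)cc(Cl)c3)[C@@H]2c2ccccc2)cc1` gives 11000 nM, the only numeric value in this set. Compound 1 `Clc1cc(Cl)cc(CO[C@H]2CCCN(Cc3ncco3)[C@H]2c2ccccc2)c1` gives > 200000 nM, which is a limit of the assay rather than a number. Compound 3 `CN1CCC[C@H](O[C@H](CO)c2cc(Cl)cc(Cl)c2)[C@@H]1c1ccccc1` has not yet been measured; it differs from compound 2 by hydrogen in place of 4-carboxyphenyl on a saturated chain carbon bound to an amine nitrogen in a ring. Among the measured compounds shown here, with no step between measured compounds to draw on, the expectation is a move toward weaker effect in this assay, probably beyond the usual scatter, meaning a step of a 3.6-fold higher number from compound 2 to compound 3 (0.56 log units; beyond the scatter). Compound 3 is therefore expected at 40000 nM, within a range from 10000 nM to 200000 nM.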

Compound 3, half-maximal effective concentration: 42000 nM
Estimate against measurement, compound 3: 1.1-fold (0.02 log units) below; measured number inside the range.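

In this assay, cutting 4-carboxybenzyl to methyl gives a 3.8-fold higher number from compound 2 to compound 3 (0.58 log units; beyond the scatter), so this place on the amine nitrogen in a ring does affect the read-out, though only modestly. The 4-carboxyphenyl group helps but is not needed for a measurable effect, since compound 3 still gives a number rather than a limit, unlike the one value that stops at the edge of the assay: the limit of > 200000 nM in this assay, at which 1 of the 3 values shown sits.

Going by these compounds, whether the difference belongs to the carboxylic acid or to the aromatic ring stays open. A plain benzyl group at this place would separate the two, and an ethyl or longer chain would show how the effect changes with size between methyl and benzyl.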